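The compounds below may be only part of what the source reports. "The series", "measured", "known", "first", "only" and "open" are said of these compounds alone.

Measured compounds:
compound 1 `NCc1ccccc1CN(Cc1nc2ccccc2[nH]1)C1CCCc2cccnc21`, in a functional assay on CEM-CCRF cells for antagonist activity at C-X-C chemokine receptor type 4 (Homo sapiens), read by calcium flux (on this read-out higher numbers stand for weaker inhibition and lower numbers for stronger inhibition), compound 1 gives 50 nM
compound 2 `NC/C=C\CN(Cc1nc2ccccc2[nH]1)C1CCCc2cccnc21`, in this assay compound 2 gives 77 nM
compound 3 `NC/C=C/CN(Cc1nc2ccccc2[nH]1)C1CCCc2cccnc21`, in this assay compound 3 gives 160 nM

Compound 2 stands second highest of these three numbers. It is nearest compound 1, with a 1.5-fold higher number from compound 1 to compound 2 (0.19 log units; within the scatter), and furthest from compound 3, with a 2.1-fold higher number from compound 2 to compound 3 (0.32 log units; beyond the scatter); the pair 2 and 3 differ only in the fact that one of compounds 2 and 3 is drawn with a defined configuration and the other without, at the place where they differ.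

Compound 4 `NCCCC(=O)N(Cc1nc2ccccc2[nH]1)C1CCCc2cccnc21` has not yet been measured. It differs from compound 2 in one place: (3-aminopropyl)carbonyl in place of 4-aminobut-2-en-1-yl on an amine nitrogen. For the measured compounds named here, none of the measured steps makes a change of this kind, in which the amine nitrogen becomes attached to a carbonyl. The steps that come closest are those that alter the chain on that same nitrogen: a 1.5-fold higher number from compound 1 to compound 2 (0.19 log units; within the scatter) and a 3.2-fold higher number from compound 1 to compound 3 (0.51 log units; beyond the scatter), both modest. The present change is larger in kind than those, so a higher number is expected, most likely beyond the scatter, though with wide uncertainty in either direction. The expected step is a 5.2-fold higher number from compound 2 to compound 4 (0.72 log units; beyond the scatter). Compound 4 is therefore estimated at 400 nM, in the range 80 nM to 3000 nM.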

Compound 4, half-maximal inhibitory concentration: 3200 nM
For compound 4 the middle estimate is 8.0-fold (0.90 log units) below the measured one, outside the stated range (above it).
By their numbers in this assay, from the lowest: compounds 1 and 2 (each within the scatter of the next); then compound 3; then compound 4.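

In this assay a carbonyl set directly on the amine nitrogen matters far more than the earlier changes of chain there: (3-aminopropyl)carbonyl in place of 4-aminobut-2-en-1-yl gives a 42-fold higher number from compound 2 to compound 4 (1.62 log units; beyond the scatter) and so much weaker inhibition. The other two chains compare the same way, with a 20-fold higher number from compound 3 to compound 4 (1.30 log units; beyond the scatter) and a 64-fold higher number from compound 1 to compound 4 (1.81 log units; beyond the scatter), so among these compounds this position accepts a benzyl or butenyl chain far better than this carbonyl-linked one. Nothing in the evidence at hand bears on the reason for this loss.

Going by these compounds, it remains open whether the carbonyl alone carries the drop or the loss of the chain's carbon-carbon double bond shares it; a 4-aminobutyl group on the same nitrogen would separate the two. On these data alone, whether a longer chain behind the carbonyl behaves alike is also open.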